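A few compounds are considered here, and "the series" means these few. Any claim that something is new, unique, unknown or untested is made for them only; others in the source may bear on it.

Three compounds share one core and differ only in the group on one aromatic carbon. Compound 1 `CCC1CCN(c2cc(C(F)(F)F)ccc2CNC(=O)C(C)c2ccc(NS(C)(=O)=O)c(F)c2)CC1` carries 4-ethylpiperidin-1-yl there; in an assay on CHO cells for antagonist activity at transient receptor potential cation channel subfamily V member 1 (Homo sapiens), read by FLIPR (a higher number here means a weaker inhibitor, a lower number a stronger inhibitor), compound 1 gives 0.7 nM. Compound 2 `CC(C(=O)NCc1ccc(C(F)(F)F)cc1N1CCC(C)(C)CC1)c1ccc(NS(C)(=O)=O)c(F)c1` carries 4,4-dimethylpiperidin-1-yl, and in this assay compound 2 gives 1.3 nM. Compound 3 `CC(C)CCSc1cc(C(F)(F)F)ccc1CNC(=O)C(C)c1ccc(NS(C)(=O)=O)c(F)c1` carries isopentylsulfanyl; in this assay compound 3 gives 1.4 nM. Compound 3 stands apart from neither neighbour: the step of a 2.0-fold higher number from compound 1 to compound 3 (0.30 log units; within the scatter) and the step of a 1.1-fold higher number from compound 2 to compound 3 (0.03 log units; within the scatter) are both within the scatter, as is a 1.9-fold higher number from compound 1 to compound 2 (0.27 log units; within the scatter), so the three numbers cannot be told apart.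

Compound 4 `CC(C(=O)NCc1ccc(C(F)(F)F)cc1SCc1ccccc1)c1ccc(NS(C)(=O)=O)c(F)c1` keeps the sulfur and changes only the chain attached to it: phenyl in place of isobutyl on a saturated chain carbon bound to a sulfur. Among the measured compounds shown here, none of the measured steps alters this chain; each swaps the whole group on the aromatic carbon, and across those swaps the numbers in this assay hardly move. That guidance is indirect, yet it points to a small step at most, in either direction, rather than a clear shift.

The estimate for compound 4 in this assay is 1.6 nM, with a range from 0.5 nM to 5 nM. The expected step of a 1.1-fold higher number from compound 3 to compound 4 (0.06 log units; within the scatter) is thus one that stays within the scatter.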

Compound 4, inhibition constant: 0.5 nM
Estimate against measurement, compound 4: 3.2-fold (0.51 log units) above; the measured number falls inside the stated range.
By their numbers in this assay, from the lowest: compounds 4, 1, 2 and 3 (each within the scatter of the next, the first and the last beyond it).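

Until now, swapping the whole group on the aromatic carbon left every step in this assay inside the scatter, so this position looked insensitive to change. Among the compounds shown here, changing only the chain on the sulfur, with phenyl in place of isobutyl on a saturated chain carbon bound to a sulfur, gives the first steps beyond the scatter: a 2.8-fold lower number from compound 3 to compound 4 (0.45 log units; beyond the scatter) and, against the piperidine with two methyl groups, a 2.6-fold lower number from compound 2 to compound 4 (0.41 log units; beyond the scatter) are both modest, while a 1.4-fold lower number from compound 1 to compound 4 (0.15 log units; within the scatter) stays within the scatter, so compound 4 and compound 1 cannot be told apart. The numbers therefore respond to the far end of the sulfur-linked group, but nothing among these compounds explains the modest step from isopentylsulfanyl to benzylsulfanyl.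

Going by these compounds, whether the lower number follows from the six-membered aromatic ring itself or from how it is held on the sulfur stays open, and a 2-phenylethyl chain on the sulfur or a cyclohexylmethyl group there would separate those two readings. On these data alone, it is also open whether a pyridine ring in place of the phenyl, or an oxygen in place of the sulfur, would keep a number in this range.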